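Swapping methyl for chloro at the assay limit

The source may report more compounds than this note shows. Statements on the series, on what has been measured and on what is new or still open speak of the compounds shown alone.

Compound 1 `O=C(NNc1ccccc1Cl)c1ccc(NS(=O)(=O)c2cnc(O)nc2O)cc1`: 7230 nM
Compound 2 `O=C(NNc1ccccc1F)c1ccc(NS(=O)(=O)c2cnc(O)nc2O)cc1`: > 20000 nM
Compound 3 `Cc1cccc(NNC(=O)c2ccccc2NS(=O)(=O)c2cnc(O)nc2O)c1`: > 20000 nM

These results come from a functional assay on OVCAR-3 cells (Homo sapiens) for antiproliferative activity, read by MTT assay, with a stated time of 24 h; on this read-out higher numbers stand for weaker inhibition and lower numbers for stronger inhibition. Compound 1 is the only one of the three with a true number. The entry for compound 2 is a limit of the assay and not a number. Compound 3 stands at > 20000 nM, which is also a limit and not a number. That position is the limit of > 20000 nM in this assay, at which 2 of the 3 values shown sit.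

Compound 4 `O=C(NNc1cccc(Cl)c1)c1ccccc1NS(=O)(=O)c1cnc(O)nc1O` keeps the structure of compound 3 but carries chloro in place of methyl on an aromatic carbon. The change turns 3-methylphenyl into 3-chlorophenyl.

For the measured compounds named here, one measured step bears on this: an at least 2.7-fold higher number from compound 1 to compound 2 (0.44 log units; beyond the scatter), with fluoro in place of chloro on an aromatic carbon. It is only indirect evidence, since it does not involve methyl and its two compounds also differ from compound 3 elsewhere in the structure. It still hints that a chloro compound can reach a measurable number here, so a modest move towards a lower number is expected in this assay. Compound 4 could nevertheless stay at the limit. The expected change is an at least 1.2-fold lower number from compound 3 to compound 4 (0.09 log units; that floor lies within the scatter). Compound 4 is estimated at 16000 nM, with an expected range of 6000 nM to 30000 nM.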

Compound 4, half-maximal inhibitory concentration: 5520 nM
Compound 4: the middle estimate sits 2.9-fold (0.46 log units) above what was measured, and the stated range ends above it.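

For the compounds shown here, until this result, the only compound with 3-methylphenyl had given no number, so nothing showed whether this part of the molecule could respond at all in this assay on its own terms. Chloro in place of methyl on this aromatic carbon gives an at least 3.6-fold lower number from compound 3 to compound 4 (0.55 log units; beyond the scatter) and so shows that exchanging one heavy atom for another at this place is enough to bring a compound from the limit to a true number. The size of the step is only a floor, and the real gap may be wider, because the starting point is a limit and not a number: the limit of > 20000 nM in this assay, at which 2 of the 4 values shown sit.

As far as these compounds go, what stays open is whether this gain is particular to chloro or would also appear with other groups at the same place, such as bromo, methoxy, an amine or a carboxylic acid. Also open, from the compounds shown here alone, is whether the same exchange would give a step of similar size in other cell lines or over a different exposure time, which a single read-out on one cell line cannot tell.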